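Adding a methyl to the phenylsulfonyl group of compound 3

The source may hold more compounds than are shown below. What is called first, only, known or untested is meant among the compounds shown, and "the series" means these compounds.

In a functional assay on SMMC-7721 cells (Homo sapiens) for cytotoxicity, read by MTT assay, with a stated time of 24 h (a higher number here means a weaker inhibitor, a lower number a stronger inhibitor), compound 3 `O=C1/C(=C/c2cccnc2)CN(S(=O)(=O)c2ccccc2)C/C1=C\c1ccccc1C(F)(F)F` gives 10900 nM. Compound 1 `Cc1ccc(S(=O)(=O)N2C/C(=C\c3cccnc3)C(=O)/C(=C/c3ccccc3F)C2)cc1` gives 10300 nM, within the scatter of compound 3, while compound 2 `O=C1/C(=C/c2cccnc2)CNC/C1=C\c1ccccc1C(F)(F)F` gives 5100 nM. Compound 4 `Cc1ccc(S(=O)(=O)N2C/C(=C\c3cccnc3)C(=O)/C(=C/c3ccccc3C(F)(F)F)C2)cc1` differs from compound 3 by methyl in place of hydrogen on an aromatic carbon, with the methyl para to a large group. For the measured compounds named here, no measured step isolates this methyl. Going by the values given here, the only measured step, a 2.1-fold higher number from compound 2 to compound 3 (0.33 log units; beyond the scatter), is modest and concerns phenylsulfonyl in place of hydrogen on a ring amine nitrogen. Compound 1 already carries (4-methylphenyl)sulfonyl but differs elsewhere too, so it offers only indirect support with 10300 nM. No shift beyond the scatter is expected in this assay. The expected change is a 1.0-fold lower number from compound 3 to compound 4 (0.02 log units; within the scatter). For compound 4 the estimated value is 10500 nM, with an expected range of 6000 nM to 18000 nM.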

Compound 4, half-maximal inhibitory concentration: 6700 nM
The estimate for compound 4 lay 1.6-fold (0.20 log units) above the measured number; low and high end bracket the measured number.
By their numbers in this assay, from the lowest: compounds 2, 4, 1 and 3 (each within the scatter of the next, the first and the last beyond it).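

In this assay, methyl in place of hydrogen on this aromatic carbon gives a 1.6-fold lower number from compound 3 to compound 4 (0.21 log units; within the scatter), so this change stays within the scatter. With (4-methylphenyl)sulfonyl on the ring amine nitrogen, the step is a 1.3-fold higher number from compound 2 to compound 4 (0.12 log units; within the scatter), against a 2.1-fold higher number from compound 2 to compound 3 (0.33 log units; beyond the scatter) for phenylsulfonyl, and trifluoromethyl in place of fluoro gives a 1.5-fold lower number from compound 1 to compound 4 (0.19 log units; within the scatter). No supporting data bear on the reason for these steps. From the compounds shown here alone, whether an amine or a carboxylic acid on this same aromatic carbon would shift the number beyond the scatter remains open.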